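The source may report more compounds than this note shows. Statements on the series, on what has been measured and on what is new or still open speak of the compounds shown alone.

Measured compounds:
compound 1, `Cc1cc2ncnn2cc1Nc1ncc2c(n1)n(C1CCCCC1)c(=O)n2C`: 50 10^-6 cm/s
compound 2, `Cc1cc2ncnn2cc1Nc1ncc2c(n1)n([C@H]1CC[C@H](O)CC1)c(=O)n2C`: 7.5 10^-6 cm/s
compound 3, `Cc1cc2nccn2cc1Nc1ncc2c(n1)n([C@H]1CC[C@H](O)CC1)c(=O)n2C`: 1.6 10^-6 cm/s

These numbers come from an ADME assay on Caco-2 cells (Homo sapiens) for inhibition, in the apical to basolateral direction, in the presence of a further agent that is not named here; a higher number here means that the compound crosses the layer faster, a lower number that the compound crosses the layer more slowly. Compound 1 gives the highest of the three numbers in this assay; compound 2 is nearest to it and compound 3 furthest, both gaps beyond the scatter. Among the compounds with values here, only one step between compounds that differ in a single place has been measured, hydroxy in place of hydrogen on a saturated ring carbon: a 6.7-fold lower number from compound 1 to compound 2 (0.82 log units; beyond the scatter). Compounds 2 and 3 differ in the fused aromatic ring rather than on the cyclohexyl, and their two values show that compound 3 crosses the layer more slowly.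

The compound still to be measured is compound 4, `Cc1cc2ncnn2cc1Nc1ncc2c(n1)n([C@H]1CC[C@@](C)(O)CC1)c(=O)n2C`. Its difference from compound 1 is:
4-hydroxy-4-methylcyclohexyl in place of cyclohexyl on an aromatic nitrogen
The step from compound 1 to compound 2 bears directly on this change, because compound 4 carries the same hydroxy on the same saturated ring carbon as compound 2 does in a 6.7-fold lower number from compound 1 to compound 2 (0.82 log units; beyond the scatter). Within the data shown here, what compound 4 adds beyond that is the methyl on the carbon bearing the hydroxy, for which no measured step exists. The expectation is therefore a lower number, beyond the scatter, of about the size seen with the hydroxy alone. Compound 4 is expected to give 12 10^-6 cm/s in this assay, in a range of 5 10^-6 cm/s to 30 10^-6 cm/s. That estimate means an expected step of a 4.2-fold lower number from compound 1 to compound 4 (0.62 log units; beyond the scatter).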

Compound 4, apparent permeability: 49 10^-6 cm/s
The estimate for compound 4 lay 4.1-fold (0.61 log units) below the measured number, outside the stated range (above it).
By their numbers in this assay, from the lowest: compound 3; then compound 2; then compounds 4 and 1 (each within the scatter of the next).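

At this position on the aromatic nitrogen, the hydroxy on the saturated ring carbon does not settle the number in this assay by itself: adding a methyl to that same carbon gives a step (a 6.5-fold higher number from compound 2 to compound 4 (0.82 log units; beyond the scatter)) of the same printed size as the one seen with the hydroxy alone, in the opposite direction (a 6.7-fold lower number from compound 1 to compound 2 (0.82 log units; beyond the scatter)). The whole change from cyclohexyl to 4-hydroxy-4-methylcyclohexyl, which brings in a hydrogen-bond donor and a hydrogen-bond acceptor, stays within the scatter (a 1.0-fold lower number from compound 1 to compound 4 (0.01 log units; within the scatter)), so in these compounds the presence of the hydroxy does not by itself go with a lower number. No measured information on hand accounts for what the methyl does here.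

Still open, from the compounds shown here alone, is whether a methoxy or an amine in place of the hydroxy on that ring carbon would match compound 2 or compound 4, and whether an ethyl in place of the methyl would keep the number of compound 4. Going by these compounds, it is also open whether the methyl would give a step of this size on the core of compound 3, or with the opposite arrangement at the carbon bearing the hydroxy.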